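Swapping Hydroxyphenyl for Dimethoxyphenyl on a Shared Core

A few compounds are considered here, and "the series" means these few. Any claim that something is new, unique, unknown or untested is made for them only; others in the source may bear on it.

Compound 1 `CC(C)CCn1cnc2c(Nc3cccc(O)c3)nc(N[C@H]3CC[C@H](N)CC3)nc21` gives 14700 nM in a functional assay on BT-474 cells (Homo sapiens) for inhibition, read by fluorescence, with a stated time of 72 h; a lower number here means a stronger inhibitor of growth, a higher number a weaker inhibitor of growth.
Compound 2 `CCCCn1cnc2c(Nc3cccc(Cl)c3)nc(N[C@H]3CC[C@H](N)CC3)nc21` gives 5100 nM in this assay.
Compound 3 `COc1ccc(Cn2cnc3c(Nc4cccc(Cl)c4)nc(N[C@H]4CC[C@H](N)CC4)nc32)cc1` gives 8200 nM in this assay.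

Compound 1 carries the highest of the three numbers; its gap to compound 3 stays within the scatter, while its gap to compound 2 lies beyond it. Compound 4 `COc1cc(Nc2nc(N[C@H]3CC[C@H](N)CC3)nc3c2ncn3CCC(C)C)cc(OC)c1` arises from compound 1 by 3,5-dimethoxyphenyl in place of 3-hydroxyphenyl on a nitrogen on an aromatic ring. For the measured compounds named here, the only measured step, a 1.6-fold higher number from compound 2 to compound 3 (0.21 log units; within the scatter), concerns the chain on the aromatic nitrogen, not the ring on the amino nitrogen, so no measured step bears directly on this change. Compounds 1 and 2 differ in two places at once, so their values alone show no single effect. A step of a 1.5-fold lower number from compound 1 to compound 4 (0.17 log units; within the scatter) is therefore expected, not beyond the scatter. Compound 4 is estimated at 10000 nM, between 3000 nM and 30000 nM.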

Compound 4, concentration for 50% growth inhibition: 5900 nM
Estimate against measurement, compound 4: 1.7-fold (0.23 log units) above; the range from low to high includes it.
By their numbers in this assay, from the lowest: compounds 2, 4, 3 and 1 (each within the scatter of the next, the first and the last beyond it).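

For the compounds shown here, this is the first measured step at this place, on a nitrogen on an aromatic ring: 3,5-dimethoxyphenyl in place of 3-hydroxyphenyl gives a 2.5-fold lower number from compound 1 to compound 4 (0.40 log units; beyond the scatter) in this assay. Growth inhibition therefore does not depend on the 3-hydroxyphenyl group, and the entering group, with 0 hydrogen-bond donors, gives a modest gain. Nothing measured here explains this gain.

Going by these compounds, it remains open whether both methoxy groups are needed, or whether a single methoxy group would do. A ring carrying an amine or a carboxylic acid also remains untested in the compounds shown.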